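This account rests on a few compounds, and the source may have more. Where it says the series, first, only, none or still open, it means among the compounds named here.

Compound 2, `O=C1c2ccccc2NS(=O)(=O)N1Cc1ccccc1`: in a functional assay on CCRF-CEM cells (Homo sapiens) for cytotoxicity (a lower number here means that less compound is tolerated, a higher number that more compound is tolerated), compound 2 gives > 200 ug/mL, which is a limit of the assay.
Compound 1, `O=C1c2ccccc2NS(=O)(=O)N1COCCO`: in this assay compound 1 gives > 200 ug/mL, also a limit.
Compound 3, `CC(=O)OCCOCN1c2ccccc2C(=O)N(Cc2ccccc2)S1(=O)=O`: in this assay compound 3 gives 103 ug/mL.

Compound 2 therefore sits at the limit of > 200 ug/mL in this assay, at which 2 of the 3 values shown sit, so its own number is not known, only that it lies beyond that limit. For the measured compounds named here, two measured steps touch it. The step from compound 1 to compound 2 is a step that the two limits leave unreadable from compound 1 to compound 2, because both ends are limits. Going by the values given here, the step from compound 2 to compound 3 is an at least 1.9-fold lower number from compound 2 to compound 3 (0.28 log units; that floor lies within the scatter), so compound 3 is the only measured compound with a readable number.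

Compound 4 is `C#CCOCN1C(=O)c2ccccc2NS1(=O)=O`. Its change from compound 2 is propargyloxy in place of phenyl on a saturated chain carbon bound to an amide-type nitrogen in a ring. Compound 1 carries a different oxygen-containing chain at that same place and sits at the same limit as compound 2, so a small side chain there has not yet shown any readable cytotoxicity. The expected step from compound 2 to compound 4 is a step that the limit leaves unreadable from compound 2 to compound 4, which is none beyond the scatter. Compound 4 is estimated at 250 ug/mL, in the range 150 ug/mL to 400 ug/mL, most likely again reported only as a limit.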

Compound 4, half-maximal cytotoxic concentration: > 200 ug/mL
Compound 4 was reported as a limit; the forecaster's own chance of this, stated with the estimate: 75%; the middle value is on the limit's open side.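

Compound 4 also sits at a limit in this assay, so its steps from compound 1 and from compound 2 cannot be read: the limit of > 200 ug/mL in this assay, at which 3 of the 4 values shown sit.

As far as these compounds go, whether propargyloxy in place of phenyl changes the tolerated concentration at all stays open, as does the true number of compound 1, compound 2 and compound 4.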